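The source may report more compounds than this note shows. Statements on the series, on what has been measured and on what is new or still open speak of the compounds shown alone.

Compound 1, `FC(F)=C(F)CCSc1ncc(Cl)s1`, was tested in a functional assay on MCF7 cells (Homo sapiens) for cytotoxicity, read by MTT assay, with a stated time of 48 h; a higher number here means a weaker inhibitor, a lower number a stronger inhibitor. There compound 1 reaches only a limit of the assay, > 120000 nM, not a number. Compound 2, `CC(c1nccs1)C(C#N)(C#N)CCC(F)=C(F)F`, likewise stops at a limit in this assay, > 120000 nM. Compound 3, `FC(F)(Cl)C(F)(Cl)CCSc1nc2ccccc2s1`, also gives only a limit in this assay, > 120000 nM. Compound 1 thus stands together with the other two at the limit of > 120000 nM in this assay, at which 3 of the 3 values shown sit, and nothing among the three separates them. Compound 4, `FC(F)=C(F)CCSc1nccs1`, is next to be tested. It differs from compound 1 by hydrogen in place of chloro on an aromatic carbon. Because all shown values sit at the limit of > 120000 nM in this assay, at which 3 of the 3 values shown sit, the expected step is small, a step that the limit leaves unreadable from compound 1 to compound 4, with no direction beyond the scatter. For compound 4 the estimate in this assay is 200000 nM, ranging from 60000 nM to 800000 nM.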

Compound 4, half-maximal inhibitory concentration: > 120000 nM
Compound 4: a limit, no number (the forecaster's own chance of this, stated with the estimate: 85%); the middle value does not contradict the limit.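

For the compounds shown here, compound 1 and compound 4 both stop at a limit, so no step between them can be read: the limit of > 120000 nM in this assay, at which 4 of the 4 values shown sit. The compounds shown leave open how chloro and hydrogen at this place compare, and whether any of the four has a readable potency.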